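The source may hold more compounds than are shown below. What is called first, only, known or untested is meant among the compounds shown, and "the series" means these compounds.

In a functional assay on cells (Neutrophil, Homo sapiens) for inhibition, with a stated time of 10 min (on this read-out lower numbers stand for stronger inhibition and higher numbers for weaker inhibition), compound 3 `CCOC(=O)c1cnn(CC(C)O)c1NC(=O)Nc1cccc(F)c1` gives 0.0007 nM and stands lowest of the three numbers, with compound 1 `CCOC(=O)c1cnn(CC(O)CC)c1NC(=O)Nc1ccccc1F` at 0.0016 nM and compound 2 `CCOC(=O)c1cnn(CC(O)CC)c1NC(=O)Nc1ccc(F)cc1` at 1.9 nM above it. Compound 4 `CCOC(=O)c1cnn(CC(O)CC)c1NC(=O)Nc1cccc(F)c1` differs from compound 3 by one change methyl in place of hydrogen on a saturated chain carbon, two bonds along the chain from an oxygen on a saturated carbon that turns 2-hydroxypropyl into 2-hydroxybutyl. Going by the values given here, the one measured step of a 1200-fold higher number from compound 1 to compound 2 (3.07 log units; beyond the scatter) is large but concerns the fluorophenyl, so no measured step isolates this chain change. The 2-hydroxybutyl chain does occur in compound 1 at 0.0016 nM as well as in compound 2 at 1.9 nM on different fluorophenyl groups. No shift beyond the scatter is therefore expected, and the estimate is a 1.7-fold higher number from compound 3 to compound 4 (0.23 log units; within the scatter) on this read-out. Compound 4 is expected at 0.0012 nM within an estimated range from 0.0002 nM to 0.02 nM in this assay here.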

Compound 4, half-maximal inhibitory concentration: 0.36 nM
Compound 4: the middle estimate sits 300-fold (2.48 log units) below what was measured; measured number above the stated range.
By their numbers in this assay, from the lowest: compound 3; then compound 1; then compound 4; then compound 2.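

In this assay, going by these compounds alone, the position is not indifferent to added carbon: a 510-fold higher number from compound 3 to compound 4 (2.71 log units; beyond the scatter) with the 3-fluorophenyl held constant, the first measured step that isolates 2-hydroxypropyl to 2-hydroxybutyl. On the 2-hydroxybutyl chain, a 230-fold higher number from compound 1 to compound 4 (2.35 log units; beyond the scatter) and a 5.3-fold lower number from compound 2 to compound 4 (0.72 log units; beyond the scatter) place the 3-fluorophenyl far from the 2-fluorophenyl and only modestly apart from the 4-fluorophenyl. No measured evidence accounts for these steps.

From the compounds shown here alone, whether 2-hydroxypropyl in place of 2-hydroxybutyl acts alike on the 2-fluorophenyl and 4-fluorophenyl groups remains open. So does the reading of a longer chain such as 2-hydroxypentyl, or an amine in place of the hydroxyl.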